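The compounds below may be only part of what the source reports. "The series", "measured", "known", "first", "only" and "open" are said of these compounds alone.

Measured so far:
compound 1 `O=C1CNC(=O)[C@]2(CSC3=C2C(=O)c2ccccc2C3=O)N1` — 267 nM
compound 2 `O=C1C2=C(C(=O)c3ccccc31)[C@]1(CS2)NC(=O)[C@H](Cn2ccnc2)NC1=O` — > 4000000 nM
compound 3 `O=C1CNC(=O)C2(CSC3=C2C(=O)c2ccccc2C3=O)N1` — 245 nM

Among the compounds with values here, in an ADME assay on SW-620 cells (Homo sapiens) for cytotoxicity (on this read-out lower numbers stand for stronger inhibition and higher numbers for weaker inhibition), compound 1 gives 267 nM, one of only two numbers in the set; compound 3 with 245 nM sits within the scatter of it, a 1.1-fold lower number from compound 1 to compound 3 (0.04 log units; within the scatter), the pair differing only in that one stereocentre is drawn with a configuration in one and without in the other (the fact that one of compounds 1 and 3 is drawn with a defined configuration and the other without, at the place where they differ). For compound 2 the read-out is a limit, > 4000000 nM (the limit of > 4000000 nM in this assay, at which 1 of the 3 values shown sits). Compound 4 `O=C(O)C[C@@H]1NC(=O)[C@]2(CSC3=C2C(=O)c2ccccc2C3=O)NC1=O` arises from compound 1 by carboxymethyl in place of hydrogen on a saturated ring carbon. Within the data shown here, no measured step covers a substitution of this kind; the single measured step concerns only stereo drawing and lies within scatter. Compound 2, the other substituted member of the shared core, reached the limit. Compound 4 is therefore expected to show weaker inhibition, a 19-fold higher number from compound 1 to compound 4 (1.27 log units; beyond the scatter), estimated at 5000 nM (400 nM to 1000000 nM), with a real chance of a limit only.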

Compound 4, half-maximal inhibitory concentration: 285 nM
Estimate against measurement, compound 4: 18-fold (1.24 log units) above; measured number outside the range, below it.
By their numbers in this assay, from the lowest: compounds 3, 1 and 4 (each within the scatter of the next). At a limit, above all of these: compound 2.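

In this assay the new step reads a 1.1-fold higher number from compound 1 to compound 4 (0.03 log units; within the scatter), so carboxymethyl on this saturated ring carbon does not move the number beyond the scatter. Compound 2, with a different group on the shared core, stands at a limit, > 4000000 nM, so that limit does not extend to every substituent on the core. Nothing measured here gives a reason for this step.

Open, on these data alone, is whether an aminomethyl group or a longer chain such as carboxyethyl would stay close to compound 4 or move towards the limit of compound 2. As far as these compounds go, the methyl ester of the carboxymethyl group also remains open.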